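A few compounds are considered here, and "the series" means these few. Any claim that something is new, unique, unknown or untested is made for them only; others in the source may bear on it.

Measured in an ADME assay on MT4 cells (Homo sapiens) for cytotoxicity; on this read-out lower numbers stand for higher toxicity in this test and higher numbers for lower toxicity in this test:
- Compound 1 `COC(=O)N[C@H](C(=O)NN(CCC[C@@](O)(Cc1ccccc1)C(=O)N[C@H]1c2ccccc2C[C@H]1O)Cc1ccc(Br)cc1)C(C)(C)C`: > 10000 nM
- Compound 2 `COC(=O)N[C@H](C(=O)NN(CCC[C@@](O)(Cc1ccccc1)C(=O)N[C@H]1c2ccccc2C[C@H]1O)Cc1ccc(-c2ccccn2)cc1)C(C)(C)C`: > 10000 nM

Compound 2 stands at a limit of this assay, not at a true number, with > 10000 nM. The same holds for its neighbour, and the picture so far is the limit of > 10000 nM in this assay, at which 2 of the 2 values shown sit.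

Compound 3 `COC(=O)N[C@H](C(=O)NN(CCC[C@@](O)(Cc1ccccc1)C(=O)N[C@H]1c2ccccc2C[C@H]1O)Cc1ccc(-c2cncnc2)cc1)C(C)(C)C` has pyrimidin-5-yl in place of pyridin-2-yl on an aromatic carbon, para to a large group (pyrimidin-5-yl in place of pyridin-2-yl on an aromatic carbon).

Going by the values given here, only one measured step bears on this change, since it also swaps the group at that place: a step that the two limits leave unreadable from compound 1 to compound 2. It gives no size to carry over, but it shows no sign of toxicity appearing. No change beyond the usual scatter is therefore expected, and the expected step is a step that the limit leaves unreadable from compound 2 to compound 3.

The estimate for compound 3 is 15000 nM, with an expected range of 7000 nM to 50000 nM.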

Compound 3, half-maximal cytotoxic concentration: > 10000 nM
Compound 3: no number, only a limit (the forecaster's own chance of this, stated with the estimate: 85%); the middle value is on the limit's open side.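

In this assay compound 3 gives > 10000 nM as a limit, not a number. No step among compound 1, compound 2 and compound 3 can be read, since all three share one limit: the limit of > 10000 nM in this assay, at which 3 of the 3 values shown sit.

The compounds shown leave open how far past this limit each true value lies.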